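The compounds below may be only part of what the source reports. "The series", "measured", "known", "first", "only" and "open" are said of these compounds alone.

Compound 1 `Fc1ccc(-c2nc3cnc(Nc4cc(C(F)(F)F)ccn4)cc3[nH]2)cc1F` was run in an ADME assay on microsomes from liver (Rattus norvegicus) for metabolic stability, read by LC-MS, with a stated time of 30 min, tested at 0.1 uM (on this read-out higher numbers stand for a more stable compound and lower numbers for a less stable compound), where compound 1 gives 84%. Compound 2 `Fc1ccnc(Nc2cc3[nH]c(-c4ccc(F)c(F)c4)nc3cn2)c1` carries fluoro in place of trifluoromethyl on an aromatic carbon; in this assay compound 2 gives 66%, a step of a number 18 percentage points lower from compound 1 to compound 2 (beyond the scatter). Compound 3 `FC1(F)CCC(c2nc3cnc(Nc4ccc(C(F)(F)F)cn4)cc3[nH]2)CC1` rests on another core, and the difference between the two cores is not broken down here. In this assay compound 3 gives 89%. Compound 4 `Fc1ccc(Nc2cc3[nH]c(C4CCC(F)(F)CC4)nc3cn2)nc1` differs from compound 3 by fluoro in place of trifluoromethyl on an aromatic carbon. Going by the values given here, this is the same kind of change as the one made from compound 1 to compound 2, though the surroundings differ: in the earlier pair the site is meta to a large group and opposite the ring nitrogen, while here it is two atoms from the ring nitrogen and para to a large group. For compound 4 a step of a number 17 percentage points lower from compound 3 to compound 4 (beyond the scatter) is expected. This expectation rests on the earlier step of a number 18 percentage points lower from compound 1 to compound 2 (beyond the scatter). Compound 4 is therefore estimated at 72%, with a likely range from 55% to 87%.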

Compound 4, percent of the compound remaining: 86%
Beside the measured number, compound 4's estimate is 14 percentage points below it; the measured number falls inside the stated range.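

In this assay, putting fluoro in place of trifluoromethyl on an aromatic carbon comes with a number 3 percentage points lower from compound 3 to compound 4 (within the scatter), so the loss seen on the core of compound 1 does not reappear on the core of compound 3. The size of the step did not carry from one core to the other: the same change on two cores in this assay, a number 18 percentage points lower (beyond the scatter) from compound 1 to compound 2 and a number 3 percentage points lower (within the scatter) from compound 3 to compound 4, 15 percentage points apart, beyond the scatter of two such steps

Going by these compounds alone, with only two pairs, which also differ in the site of the change, this does not show whether the core or the site accounts for the gap. The compounds shown leave open how each core responds to other groups at these sites, such as a nitrile or an amine. They also leave open whether a third core would follow compound 1 or compound 3.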